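Triazole nitrogen aryl swap in a diaryl urea series

The source may report more compounds than this note shows. Statements on the series, on what has been measured and on what is new or still open speak of the compounds shown alone.

Among the compounds with values here, compound 2 `CC(C)c1cccc(-n2cc(COc3cccc(NC(=O)Nc4ccc(Cl)c(C(F)(F)F)c4)c3)nn2)c1` stands at the low end of the two numbers so far: in a functional assay on HepG2 cells (Homo sapiens) for inhibition, read by MTT assay, with a stated time of 72 h (a higher number here means a weaker inhibitor, a lower number a stronger inhibitor), compound 2 gives 3250 nM, while compound 1 `Cc1ccc(-n2cc(COc3cccc(NC(=O)Nc4ccc(Cl)c(C(F)(F)F)c4)c3)nn2)cc1` gives 5430 nM, and the step of a 1.7-fold lower number from compound 1 to compound 2 (0.22 log units; within the scatter) falls within the scatter. Compound 3 `O=C(Nc1cccc(OCc2cn(-c3ccc(Cl)cc3)nn2)c1)Nc1ccc(Cl)c(C(F)(F)F)c1` differs from compound 2 by 4-chlorophenyl in place of 3-isopropylphenyl on an aromatic nitrogen. Within the data shown here, the single step that bears on this site is the one just noted, and it stayed within the scatter; a step of no firmer size or direction is therefore expected, a 1.2-fold higher number from compound 2 to compound 3 (0.09 log units; within the scatter). Compound 3 is estimated at 4000 nM in this assay, with a range from 1500 nM to 11000 nM.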

Compound 3, half-maximal inhibitory concentration: 2490 nM
For compound 3 the middle estimate is 1.6-fold (0.21 log units) above the measured one, and the stated range covers the measured number.
By their numbers in this assay, from the lowest: compounds 3, 2 and 1 (each within the scatter of the next, the first and the last beyond it).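

In this assay, 4-chlorophenyl on the aromatic nitrogen does not separate from 3-isopropylphenyl (a 1.3-fold lower number from compound 2 to compound 3 (0.12 log units; within the scatter)). Chloro in place of methyl on an aromatic carbon gives the only step here beyond the scatter, and it is modest (a 2.2-fold lower number from compound 1 to compound 3 (0.34 log units; beyond the scatter)). Nothing at hand explains either step.

Open, as far as these compounds go, is whether a 4-methoxyphenyl or a 4-aminophenyl on the aromatic nitrogen would give a step beyond the scatter from compound 3. Also open, from the compounds shown here alone, is whether 3-chlorophenyl would match 4-chlorophenyl.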